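The compounds below may be only part of what the source reports. "The series", "measured", "known", "first", "only" and "open" are said of these compounds alone.

In a toxicity assay on THP-1 cells (Homo sapiens) for inhibition (on this read-out higher numbers stand for lower toxicity in this test and lower numbers for higher toxicity in this test), compound 1 `Cn1c(-c2ccccc2)cnc1NC(=O)c1ccc(F)cc1` gives > 100000 nM as a limit. Compound 2 `Cn1c(-c2ccccc2F)cnc1NC(=O)c1ccc(F)cc1` gives > 100000 nM as a limit too. Compound 3 `Cn1c(-c2ccccc2Cl)cnc1NC(=O)c1ccc(F)cc1` stands only at a limit of > 50000 nM and has no number of its own. Compound 4 `Cn1c(-c2ccccc2[N+](=O)[O-])cnc1NC(=O)c1ccc(F)cc1` differs from compound 3 thus: nitro in place of chloro on an aromatic carbon (nitro in place of chloro on an aromatic carbon, ortho to a large group). The measured steps that bear on it are a step that the two limits leave unreadable from compound 1 to compound 2 and a step that the two limits leave unreadable from compound 1 to compound 3 and a step that the two limits leave unreadable from compound 2 to compound 3 and none has a size that can be read. Within the data shown here, no sized step can therefore be carried over into this assay and none beyond the scatter is expected, in either direction. The expected step is a step that the limit leaves unreadable from compound 3 to compound 4 and it rests on limits alone. For compound 4 the estimate is 60000 nM with an expected range from 20000 nM to 100000 nM and a limit is the likeliest report.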

Compound 4, half-maximal cytotoxic concentration: 31000 nM
Compound 4: middle estimate off by 1.9-fold (0.29 log units), on the high side; measured number inside the range.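

In this assay, nitro on this aromatic carbon, ortho to a large group, gives compound 4 the only number of its own among the compounds shown, while hydrogen, fluoro and chloro there leave only limits. Against fluoro and hydrogen the change gives an at least 3.2-fold lower number from compound 2 to compound 4 (0.50 log units; beyond the scatter) and an at least 3.2-fold lower number from compound 1 to compound 4 (0.50 log units; beyond the scatter), so this position can register a change in the read-out. Against chloro there is only an at least 1.6-fold lower number from compound 3 to compound 4 (0.20 log units; that floor lies within the scatter), and the steps among compound 1, compound 2 and compound 3 cannot be read. As far as these compounds go, whether chloro truly differs from nitro therefore stays open. So does how an amine or a carboxylic acid at this position would read.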